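A few compounds are considered here, and "the series" means these few. Any claim that something is new, unique, unknown or untested is made for them only; others in the source may bear on it.

Measured compounds and their readings in the cell assay:

compound 1 `COc1cc(NC(=O)Nc2cc(Nc3cc(Br)ccc3OC)ncn2)cc(OC)c1` — 43.5%
compound 2 `COc1ccc(OC)c(Nc2cc(NC(=O)Nc3c(Cl)cccc3Cl)ncn2)c1` — 74%
compound 3 `O=C(Nc1cc(Nc2ccc(F)c(Cl)c2)ncn1)Nc1c(Cl)cccc1Cl` — 39.5%

In a functional assay on NCI-H520 cells (Homo sapiens) for inhibition, read by MTT assay, with a stated time of 48 h, tested at 10 uM (a lower number here means less inhibition, a higher number more inhibition at the concentration tested (going by the name of the read-out)), compound 1 gives 43.5%, the second highest of the three numbers. The nearest number belongs to compound 3, at 39.5%, and the two lie within the scatter of each other, so nothing separates them. Going by the values given here, compound 2, at 74%, stands well beyond the scatter above compound 1; no single-point step links compound 2 to either of the others, so only the two values themselves can be compared.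

Compound 4 `COc1cc(NC(=O)Nc2cc(Nc3ccc(Br)cc3OC)ncn2)cc(OC)c1` has the same atoms as compound 1, joined differently: 4-bromo-2-methoxyphenyl in place of 5-bromo-2-methoxyphenyl on a nitrogen on an aromatic ring. Cut one bond further out, the change reads (5-bromo-2-methoxyphenyl)amino to (4-bromo-2-methoxyphenyl)amino; the rest of the molecule, including the shared core of compound 1, is unchanged. Among the compounds with values here, no measured pair in this set shows what moving the bromine on that ring does, so there is nothing to lean on beyond the reading of compound 1 itself.

The step from compound 1 to compound 4 is expected to be small, a number 1.5 percentage points higher from compound 1 to compound 4 (within the scatter), not beyond the scatter in either direction. For compound 4 the expected value in this assay is 45%, with a range from 25% to 65%.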

Compound 4, a percentage reported as inhibition, at one concentration (the size of the read-out at that concentration, not a potency): 36.1%
Compound 4: middle estimate off by 8.9 percentage points, on the high side; the measured number falls inside the stated range.
By their numbers in this assay, from the lowest: compounds 4, 3 and 1 (each within the scatter of the next); then compound 2.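

Moving the bromine, with 4-bromo-2-methoxyphenyl in place of 5-bromo-2-methoxyphenyl on a nitrogen on an aromatic ring, gives in this assay a number 7.4 percentage points lower from compound 1 to compound 4 (within the scatter). Going by these compounds alone, this is the first pair that differs in one place, and it shows that, on the shared core of compound 1, this move of the bromine does not shift the reading beyond the scatter. Nothing at hand bears on the reason for this outcome.

From the compounds shown here alone, it stays open whether an amine or a carboxylic acid in place of the bromine on this ring would move the reading beyond the scatter, and whether the same bromine move would give a similar result on a core other than that of compound 1. The much higher reading of compound 2 at 74% also remains unconnected to compound 1 or compound 4 by any one-place step, so the part of the structure that accounts for it cannot be identified from these compounds.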